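A few compounds are considered here, and "the series" means these few. Any claim that something is new, unique, unknown or untested is made for them only; others in the source may bear on it.

Compound 3 `CCOC(=O)c1c(-c2cccc(Cl)c2)[nH]c2cc(OC)ccc2c1=O` carries a 3-chlorophenyl group on the shared core. In a physicochemical assay for solubility, in phosphate buffer, at pH 7.4 (a lower number here means a less soluble compound, a higher number a more soluble compound), compound 3 gives 58000 nM. That is the highest of the two numbers measured here: compound 2 `CCOC(=O)c1c(-c2ccc(Cl)cc2)[nH]c2cc(OC)ccc2c1=O`, with a 4-chlorophenyl group in its place, gives 3000 nM, and a 19-fold higher number from compound 2 to compound 3 (1.29 log units; beyond the scatter). Compound 1 `CCOC(=O)c1c(-c2cccs2)[nH]c2cc(OC)ccc2c1=O` carries thiophen-2-yl instead. In this assay compound 1 reaches a limit of the assay, > 100000 nM. From compound 1 the steps read an at least 33-fold lower number from compound 1 to compound 2 (1.52 log units; beyond the scatter) and an at least 1.7-fold lower number from compound 1 to compound 3 (0.23 log units; that floor lies within the scatter).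

Compound 4 `CCOC(=O)c1c(-c2ccccc2)[nH]c2cc(OC)ccc2c1=O` differs from compound 3 by hydrogen in place of chloro on an aromatic carbon. Among the measured compounds shown here, none of the measured steps removes a chloro group; each exchanges one aryl group for another, and the large 19-fold higher number from compound 2 to compound 3 (1.29 log units; beyond the scatter) shows only that the place of chloro shifts the number strongly. For the measured compounds named here, no direct precedent exists for this change. The step of a 1.7-fold higher number from compound 3 to compound 4 (0.24 log units; within the scatter) is therefore expected to be modest, with the number drifting upward rather than down. Compound 4 is estimated at 100000 nM, within a range from 30000 nM to 300000 nM.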

Compound 4, solubility: > 100000 nM
Compound 4: no number, only a limit; the forecaster's own chance of this, stated with the estimate: 40%; the middle value lies on the limit itself.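

Compound 4 gives only a limit of the assay, so the phenyl group yields a floor and not a number: the limit of > 100000 nM in this assay, at which 2 of the 4 values shown sit.

In this assay the change from 4-chlorophenyl to phenyl is large, an at least 33-fold higher number from compound 2 to compound 4 (1.52 log units; beyond the scatter), while the change from 3-chlorophenyl to phenyl gives an at least 1.7-fold higher number from compound 3 to compound 4 (0.23 log units; that floor lies within the scatter). Among these compounds, compound 2 with its 4-chlorophenyl group therefore stands apart, while no readable step beyond the scatter separates the thiophen-2-yl, phenyl and 3-chlorophenyl groups of compound 1, compound 4 and compound 3.

The step between compound 1 and compound 4 cannot be read, as both values are limits. The compounds shown also leave open how a methoxy group, an amine or a carboxylic acid in place of chloro on the phenyl group would read in this assay.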